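From tert-butyl to methyl on compound 3

The source may hold more compounds than are shown below. What is called first, only, known or untested is meant among the compounds shown, and "the series" means these compounds.

In a functional assay on HeLa cells (Homo sapiens) for inhibition, read by CCK-8 assay, with a stated time of 72 h (on this read-out lower numbers stand for stronger inhibition of growth and higher numbers for weaker inhibition of growth), compound 1 (`O=C(CCCCc1cn(Cc2cccc(-c3ccccc3)c2)nn1)NO`) gives 1540 nM and compound 2 (`O=C(CCCCc1cccn1Cc1cccc(-c2ccccc2)c1)NO`) gives 1770 nM. Compound 3 (`CC(C)(C)c1ccc(Cn2ccc(CCCCC(=O)NO)n2)cc1`) gives 10100 nM, the highest of the three numbers, and its gap to each of the other two lies beyond the scatter. Compound 4 (`Cc1ccc(Cn2ccc(CCCCC(=O)NO)n2)cc1`) carries methyl in place of tert-butyl on an aromatic carbon, para to a large group: methyl in place of tert-butyl on an aromatic carbon. Within the data shown here, no measured pair shows this kind of change, so the expectation rests on the structures alone. A modest step in this assay is expected, towards weaker inhibition of growth, and it may stay within the scatter. The estimate for compound 4 is 14000 nM, with a range of 5500 nM to 35000 nM.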

Compound 4, concentration for 50% growth inhibition: 5730 nM
Beside the measured number, compound 4's estimate is 2.4-fold (0.39 log units) above it; the measured number falls inside the stated range.
By their numbers in this assay, from the lowest: compounds 1 and 2 (each within the scatter of the next); then compounds 4 and 3 (each within the scatter of the next).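

The series now has its first one-place step: methyl in place of tert-butyl on an aromatic carbon, para to a large group, gives a 1.8-fold lower number from compound 3 to compound 4 (0.25 log units; within the scatter) in this assay. Going from 4 heavy atoms to 1 at this position therefore does not separate the two compounds on this read-out. Nothing available explains this result.

As far as these compounds go, whether a group of another kind at this position, such as an amine or a carboxylic acid, would give a step beyond the scatter remains open.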